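A few compounds are considered here, and "the series" means these few. Any claim that something is new, unique, unknown or untested is made for them only; others in the source may bear on it.

Measured so far in an ADME assay on L6 cells (Rattus norvegicus) for cytotoxicity, read by resazurin assay, with a stated time of 72 h; a lower number here means a stronger inhibitor, a higher number a weaker inhibitor
Compound 1 `Clc1ccc(C(c2ccc(Cl)cc2)c2cccnc2)cc1` gives 84700 nM
Compound 2 `COc1cccc(C(O)(c2ccc(Cl)cc2)c2cccnc2)c1` gives 85600 nM

Going by the values given here, compound 2 stands within the scatter of compound 1, so these two numbers set no order between the compounds. Compound 3 (`N#Cc1cccc(C(O)(c2ccc(Cl)cc2)c2cccnc2)c1`) follows from compound 2 by one structural change, with cyano in place of methoxy on an aromatic carbon, meta to a large group (cyano in place of methoxy on an aromatic carbon). Among the compounds with values here, no measured pair of compounds shows what a change of this kind does, so any forecast here is a cautious one. The expectation rests only on compound 1 at 84700 nM and compound 2 at 85600 nM lying within the scatter of each other. In this assay the expected size is small, with a 1.1-fold lower number from compound 2 to compound 3 (0.06 log units; within the scatter) estimated and no step beyond the scatter anticipated in either direction. For compound 3 the estimated value is 75000 nM, with an expected range from 35000 nM to 130000 nM.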

Compound 3, half-maximal inhibitory concentration: > 100000 nM
Compound 3: no number, only a limit; the forecaster's own chance of this, stated with the estimate: 10%; middle value at least 1.3-fold (0.12 log units) away from the limit.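

In this assay compound 3 gives > 100000 nM and this is a limit of the assay, not a number. Cyano in place of methoxy on this aromatic carbon, meta to a large group, reads as an at least 1.1-fold higher number from compound 2 to compound 3 (0.06 log units; that floor lies within the scatter) and so gives the first step of the series, one that shows no sign of a lower number with this change at this place, although its floor alone stays within the scatter. The full size of the step cannot be read because the value rests on a limit: the limit of > 100000 nM in this assay, at which 1 of the 3 values shown sits.

As far as these compounds go, it remains open whether an amine or a carboxylic acid on the same aromatic carbon would give a value short of that limit. From the compounds shown here alone, it also remains open whether cyano would read the same at another place on this ring.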